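The source may hold more compounds than are shown below. What is called first, only, known or untested is meant among the compounds shown, and "the series" means these compounds.

Measured so far:
compound 1 `O=c1oc2ccccc2c2nc3c(ccc4cc[nH]c43)c(-c3ccc(Br)cc3)c12` — 70700 nM
compound 2 `O=c1oc2ccccc2c2nc3c(ccc4cc[nH]c43)c(-c3ccc(O)cc3)c12` — 70700 nM

In a functional assay on B16-F10 cells (Mus musculus) for cytotoxicity (on this read-out higher numbers stand for weaker inhibition and lower numbers for stronger inhibition), compound 1 gives 70700 nM. Compound 2 `O=c1oc2ccccc2c2nc3c(ccc4cc[nH]c43)c(-c3ccc(O)cc3)c12`, which carries a hydroxy in place of the bromo on an aromatic carbon, gives 70700 nM in this assay, and the step from compound 1 to compound 2 is no change at the digits printed from compound 1 to compound 2 (within the scatter). Compound 1 therefore stands level with compound 2 at the digits shown; neither can be called the more or the less potent of the two.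

The next compound, compound 3 `O=c1oc2ccccc2c2nc3c(ccc4cc[nH]c43)c(-c3ccc(F)cc3)c12`, differs from compound 1 as follows: fluoro in place of bromo on an aromatic carbon

Among the compounds with values here, the one step at hand bears on this change directly: swapping the bromo for a hydroxy on the same aromatic carbon left this assay unchanged within the scatter, no change at the digits printed from compound 1 to compound 2 (within the scatter). Fluoro on that carbon is a second change at the same place, and the data give no reason to expect a step beyond the scatter in either direction. The estimated step from compound 1 to compound 3 is therefore no change at the digits printed from compound 1 to compound 3 (within the scatter). Compound 3 is expected to give about 70700 nM in this assay, with a range from 35000 nM to 141000 nM.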

Compound 3, half-maximal inhibitory concentration: 70700 nM
Compound 3: middle estimate and measured number agree at the digits printed; low and high end bracket the measured number.
By their numbers in this assay, from the lowest: compounds 1, 2 and 3 (each within the scatter of the next).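

A third group on this aromatic carbon, para to a large group, now gives the same picture in this assay: fluoro in place of bromo gives no change at the digits printed from compound 1 to compound 3 (within the scatter), and fluoro in place of hydroxy gives no change at the digits printed from compound 2 to compound 3 (within the scatter). Where the earlier pair offered a single exchange, bromo, hydroxy and fluoro now form a set of three exchanges at one place, and none of the compounds shown goes against the reading that the read-out does not follow the group on this carbon. No measurement at hand explains why these values coincide.

From the compounds shown here alone, whether the same holds for a group of another kind on this carbon, such as an amine, a carboxylic acid or a longer chain, stays open, as does the effect of any of these groups elsewhere on the same ring. With compound 3 at 70700 nM in this assay and its two companions level with it, the compounds shown also leave open whether a change in the shared core would move this read-out at all.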